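This account rests on a few compounds, and the source may have more. Where it says the series, first, only, none or still open, it means among the compounds named here.

In a functional assay on HepG2 cells (Homo sapiens) for inhibition, read by MTT assay, with a stated time of 48 h (on this read-out higher numbers stand for weaker inhibition and lower numbers for stronger inhibition), compound 3 `Brc1ccc(CSc2nnc(-c3ccncc3)n2-c2ccccc2)cc1` gives 12900 nM, the lowest of the two numbers in hand. Compound 2 `Fc1ccc(CSc2nnc(-c3ccncc3)n2-c2ccccc2)cc1` gives 15600 nM in this assay, and the difference of a 1.2-fold lower number from compound 2 to compound 3 (0.08 log units; within the scatter) places the pair within the scatter of each other. Compound 1 `Fc1ccccc1CSc1nnc(-c2ccncc2)n1-c1ccccc1` is reported only as a limit, > 50000 nM in this assay, with the limit of > 50000 nM in this assay, at which 1 of the 3 values shown sits. Moving the fluorine from 2-fluorophenyl to 4-fluorophenyl gave an at least 3.2-fold lower number from compound 1 to compound 2 (0.50 log units; beyond the scatter), and the move to 4-bromophenyl gave an at least 3.8-fold lower number from compound 1 to compound 3 (0.58 log units; beyond the scatter).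

Compound 4 `O=[N+]([O-])c1cccc(CSc2nnc(-c3ccncc3)n2-c2ccccc2)c1` differs from compound 3 by 3-nitrophenyl in place of 4-bromophenyl on a saturated chain carbon bound to a sulfur. Going by the values given here, no measured step matches this change directly: the two steps that cross the scatter shift a halogen from one ring position to another, while the swap of bromo for fluoro was within the scatter. The change to 3-nitrophenyl leaves the 4-position open again, so the step in this assay is expected to be small, at most modest and more likely toward a higher number. For compound 4 the estimate is a step of a 1.2-fold higher number from compound 3 to compound 4 (0.07 log units; within the scatter) in this assay. Compound 4 is therefore expected at about 15000 nM in this assay, within a range of 5000 nM to 45000 nM.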

Compound 4, half-maximal inhibitory concentration: 22000 nM
Compound 4: the middle estimate sits 1.5-fold (0.17 log units) below what was measured; low and high end bracket the measured number.
By their numbers in this assay, from the lowest: compounds 3, 2 and 4 (each within the scatter of the next). At a limit, above all of these: compound 1.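

Placed on a saturated chain carbon bound to a sulfur, 3-nitrophenyl is the first group here that is not a halogen, and it brings 9 heavy atoms and 2 hydrogen-bond acceptors where 4-bromophenyl has 7 heavy atoms and no hydrogen-bond acceptors. Even so, this assay gives a 1.7-fold higher number from compound 3 to compound 4 (0.23 log units; within the scatter) and a 1.4-fold higher number from compound 2 to compound 4 (0.15 log units; within the scatter), so neither a halogen nor a group in the 4-position is needed to stay within the scatter of compound 2 and compound 3, whereas the step of an at least 2.2-fold lower number from compound 1 to compound 4 (0.35 log units; beyond the scatter) sets 2-fluorophenyl apart from 3-nitrophenyl as well as from the two 4-halophenyl groups. Compound 1 remains a limit of the assay and not a number: the limit of > 50000 nM in this assay, at which 1 of the 4 values shown sits.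

The compounds shown leave open whether the gap at 2-fluorophenyl belongs to the 2-position or to that particular group, since 2-bromophenyl and 2-nitrophenyl are not among them. They also leave open how this place would respond to an aminomethyl or carboxylic acid group on the phenyl ring, or to a longer chain in place of the single saturated carbon bound to the sulfur.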